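Amine-nitrogen substituent exchange on the piperidine: compound 3 outlook

The source may hold more compounds than are shown below. What is called first, only, known or untested is meant among the compounds shown, and "the series" means these compounds.

Measured so far:
Compound 1, `O=C(c1ccc(Cl)cc1)N1CCC(NS(=O)(=O)c2cc(S(=O)(=O)c3ccccc3)ccc2C(F)(F)F)CC1` — in an assay on isolated protein for displacement of a labelled ligand from secreted frizzled-related protein 1 (Homo sapiens), read by fluorescence polarization, with a stated time of 30 min (on this read-out higher numbers stand for weaker inhibition and lower numbers for stronger inhibition), compound 1 gives 300 nM.
Compound 2, `O=C(O)c1ccc(N2CCC(NS(=O)(=O)c3cc(S(=O)(=O)c4ccccc4)ccc3C(F)(F)F)CC2)cc1` — in this assay compound 2 gives 120 nM.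

Among the compounds with values here, compound 2 holds the lowest of the two numbers in this assay; its only neighbour is compound 1, and the gap is the step of a 2.5-fold lower number from compound 1 to compound 2 (0.40 log units; beyond the scatter), which lies beyond the scatter.

Compound 3 is `O=C([C@@H]1CCNC1)N1CCC(NS(=O)(=O)c2cc(S(=O)(=O)c3ccccc3)ccc2C(F)(F)F)CC1`. It keeps the shared core and differs from compound 2 only at the amine nitrogen in the ring: (pyrrolidin-3-yl)carbonyl in place of 4-carboxyphenyl on an amine nitrogen in a ring.

Within the data shown here, only one measured step bears on this position, a 2.5-fold lower number from compound 1 to compound 2 (0.40 log units; beyond the scatter), and it concerns an exchange between two groups that each carry a six-membered aromatic ring. Neither measured compound carries a five-membered non-aromatic ring at this position, so the measured pair gives direction only loosely. The step from compound 2 to compound 3 is therefore expected to be small or back toward the number of compound 1, with a wide band.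

For compound 3 the estimate in this assay is 250 nM, within 80 nM to 800 nM, which would be an expected step of a 2.1-fold higher number from compound 2 to compound 3 (0.32 log units; beyond the scatter).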

Compound 3, half-maximal inhibitory concentration: 60 nM
Beside the measured number, compound 3's estimate is 4.2-fold (0.62 log units) above it; measured number below the stated range.
By their numbers in this assay, from the lowest: compounds 3 and 2 (each within the scatter of the next); then compound 1.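

In this assay the exchange of 4-carboxyphenyl for (pyrrolidin-3-yl)carbonyl is a 2.0-fold lower number from compound 2 to compound 3 (0.30 log units; within the scatter) so compounds 2 and 3 cannot be told apart, and a group with no aromatic ring serves at this position as well as the 4-carboxyphenyl group. With the carbonyl kept in place, pyrrolidin-3-yl in place of 4-chlorophenyl is a 5.0-fold lower number from compound 1 to compound 3 (0.70 log units; beyond the scatter) and this shows that the number of compound 1 is not set by the carbonyl alone, which the earlier pair could not separate from the change of ring. Nothing on hand accounts for either step.

Open, going by these compounds, is whether the ring nitrogen of the pyrrolidin-3-yl group matters, which a cyclopentyl group on the same carbonyl would show, and whether the defined stereocentre matters, which the mirror-image pyrrolidin-3-yl form would show. Also open, on these data alone, is whether a carboxylic acid on the five-membered ring, or an open chain ending in an amine on the same carbonyl, keeps the number in the range of compounds 2 and 3.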